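A few compounds are considered here, and "the series" means these few. Any claim that something is new, unique, unknown or untested is made for them only; others in the source may bear on it.

In a functional assay with Mus musculus as the target (a higher number here means that more compound is needed for the effect, a lower number that less compound is needed), compound 1 (`Nc1nc(O)c2c(n1)n(C1OC(CO)[C@@H](O)[C@H]1O)c(=O)n2C/C=C/c1ccccc1`) gives 4 uM and compound 3 (`C=CCn1c(=S)n(C2OC(COC(C)=O)[C@H]3OC(C)(C)O[C@@H]23)c2nc(N)nc(O)c21`) gives 50 uM while compound 2 (`C=CCn1c(=O)n([C@H]2CO[C@@H](CO)C2)c2nc(N)nc(O)c21`) gives 272 uM as the highest number of the three. Compound 4 (`C=CCn1c(=O)n(C2C=CC(CO)O2)c2nc(N)nc(O)c21`) has not yet been measured. It differs from compound 2 by a group of 7 heavy atoms (5 carbon, 2 oxygen; one five-membered non-aromatic ring with 1 hetero atom) in place of a group of 7 heavy atoms (5 carbon, 2 oxygen; one five-membered non-aromatic ring with 1 hetero atom), on an aromatic nitrogen while the allyl group stays in place, and the entering group adds a double bond outside aromatic rings. For the measured compounds named here, no measured pair shows this kind of change, so the expectation in this assay is only a small move toward a lower number, perhaps none beyond the scatter. The estimated step is a 1.6-fold lower number from compound 2 to compound 4 (0.20 log units; within the scatter) on this expectation. For compound 4 the expected value is 170 uM (estimated range 50 uM to 500 uM).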

Compound 4, concentration for half-maximal effect: 30 uM
For compound 4 the middle estimate is 5.7-fold (0.75 log units) above the measured one; measured number below the stated range.
By their numbers in this assay, from the lowest: compound 1; then compounds 4 and 3 (each within the scatter of the next); then compound 2.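

In this assay, for the compounds shown here, the exchange on the aromatic nitrogen, with the allyl group in place, gives a 9.1-fold lower number from compound 2 to compound 4 (0.96 log units; beyond the scatter), the first single-place comparison. It shows that this position responds even when the two rings have the same heavy-atom, donor and acceptor counts, and the entering ring adds a double bond outside aromatic rings. No measurement here explains the step. The compounds shown leave open whether the double bond alone accounts for it. They also leave open how an open butyl chain or an amine-bearing ring would behave on this nitrogen.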